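The compounds below may be only part of what the source reports. "The series", "measured", "known", "first", "only" and "open" are said of these compounds alone.

Measured compounds:
Compound 1 `CNC(=O)c1cc(OCCCCOc2ccc(C(=O)CC(C)(C)C)c(O)c2C)ccc1F`: 476 nM
Compound 2 `COc1ccc(OCCCCOc2ccc(C(=O)CC(C)(C)C)c(O)c2C)cc1C(=O)O`: 490 nM

In an assay for positive allosteric modulation of metabotropic glutamate receptor 3 (Rattus norvegicus) (a higher number here means that more compound is needed for the effect, a lower number that less compound is needed), compound 1 gives the lower of the two numbers shown, but the number for compound 2 lies within the usual scatter of it, so the two compounds cannot be told apart on this read-out. Both share the same core, a ketone-bearing phenol joined through a four-carbon chain to a second aromatic ring, and differ only in the substituents on that second ring.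

Compound 3 `Cc1c(OCCCCOc2ccc(F)c(C(N)=O)c2)ccc(C(=O)CC(C)(C)C)c1O` has not been measured in this assay. It differs from compound 1 in one place: hydrogen in place of methyl on an amide-type nitrogen, that is, methylcarbamoyl becomes carbamoyl, with the methyl leaving the amide-type nitrogen and a hydrogen taking its place. For the measured compounds named here, no pair of measured compounds shows this kind of change, so there is no measured step to lean on. The change is a small one, and the expected step from compound 1 to compound 3 is a 1.2-fold higher number from compound 1 to compound 3 (0.06 log units; within the scatter), not clearly beyond the scatter in either direction. Compound 3 is therefore estimated at 550 nM, with a range from 200 nM to 1500 nM.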

Compound 3, half-maximal effective concentration: "not active" (no number reported)
No number was reported for compound 3, and the estimate cannot be compared.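

For the compounds shown here, compound 3 was reported as "not active" in this assay with no number, so no step from compound 1 to compound 3 can be read. Nothing among the data shown accounts for this result. The compounds shown leave open how other groups on the amide-type nitrogen would read out in this assay.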